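Swapping chloro for fluoro on a weak inhibitor

The source may hold more compounds than are shown below. What is called first, only, known or untested is meant among the compounds shown, and "the series" means these compounds.

Of the compounds shown here, three have been measured in a functional assay on HeLa cells (Homo sapiens) for inhibition; a higher number here means a weaker inhibitor, a lower number a stronger inhibitor. Compound 1 `O=C1O/C(=C\Cn2cc(Br)c(=O)[nH]c2=O)C(OCc2ccccc2)=C1OCc1ccccc1` gives 30000 nM in this assay. Compound 2 `O=C1O/C(=C\Cn2cnc3c(-n4cccc4)ncnc32)C(OCc2ccccc2)=C1OCc1ccccc1` gives 70000 nM in this assay. Compound 3 `O=C1O/C(=C\Cn2cc(Cl)c(=O)[nH]c2=O)C(OCc2ccccc2)=C1OCc1ccccc1` gives 40000 nM in this assay, which places it second highest of the three numbers, nearest to compound 1 and furthest from compound 2, with both gaps within the scatter. Compound 4 `O=C1O/C(=C\Cn2cc(F)c(=O)[nH]c2=O)C(OCc2ccccc2)=C1OCc1ccccc1` has not yet been measured. The change is fluoro in place of chloro on an aromatic carbon. For the measured compounds named here, the one measured step that bears on it is the related halogen exchange a 1.3-fold higher number from compound 1 to compound 3 (0.12 log units; within the scatter), which stayed within the scatter. Another exchange of one halogen for another at the same position is therefore expected to give a step in this assay of no clear direction, no change at the digits printed from compound 3 to compound 4 (within the scatter), not beyond the scatter. Compound 4 is estimated at 40000 nM in this assay, with a range from 15000 nM to 110000 nM.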

Compound 4, half-maximal inhibitory concentration: 40000 nM
Compound 4: middle estimate and measured number agree at the digits printed, and the stated range covers the measured number.
By their numbers in this assay, from the lowest: compounds 1, 3, 4 and 2 (each within the scatter of the next, the first and the last beyond it).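

In this assay fluoro in place of chloro gives no change at the digits printed from compound 3 to compound 4 (within the scatter) and fluoro in place of bromo gives a 1.3-fold higher number from compound 1 to compound 4 (0.12 log units; within the scatter) on the same aromatic carbon. The earlier compounds had shown only that bromo and chloro could not be told apart at this position, and the series now shows the same for fluoro, so that none of the three halogens stands apart from the others in this assay. No measurement offers an explanation for why these three compounds read alike.

On these data alone, whether a group other than a halogen at this position, such as an amine, a methyl or a carboxylic acid, would move the number beyond the scatter remains open. The compounds shown also leave open whether a change elsewhere on the shared core would do so.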